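A few compounds are considered here, and "the series" means these few. Any claim that something is new, unique, unknown or untested is made for them only; others in the source may bear on it.

Three stilbene analogues were tested in a functional assay on M21 cells (Homo sapiens) for inhibition, read by sulforhodamine B assay, with a stated time of 48 h; a lower number here means a stronger inhibitor, a higher number a weaker inhibitor. Compound 3 `O=C1NCCN1c1ccc(/C=C\c2cccc(Cl)c2)cc1` gives 27 nM. Compound 1 `CCNC(=O)Nc1ccc(/C=C\c2cccc(Cl)c2)cc1` gives 35000 nM. Compound 2 `Cc1cc(C)cc(/C=C/c2ccc(N3CCNC3=O)cc2)c1` gives 17000 nM. The difference between the core of compound 2 and the core of compound 3 is not broken down here; their values show that compound 2 lies well above compound 3 and also above compound 1.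

The change from compound 3 to compound 1 is (ethylcarbamoyl)amino in place of 2-oxoimidazolidin-1-yl on an aromatic carbon, and it made the number rise sharply: a 1300-fold higher number from compound 3 to compound 1 (3.11 log units; beyond the scatter). The unmeasured compound 4 `CCNC(=O)Nc1ccc(/C=C/c2cc(C)cc(C)c2)cc1` carries the same kind of change relative to compound 2, namely ((ethylcarbamoyl)amino in place of 2-oxoimidazolidin-1-yl on an aromatic carbon). The two changes are not the same in every respect, since in compound 1 the group sits para to a group of 9 heavy atoms, whereas in compound 4 it sits para to a large group, so the kind of change is the same but the surroundings differ.

Compound 2 is already among the weaker inhibitors, and a rise on the scale seen from compound 3 to compound 1 would carry compound 4 far beyond what this assay can resolve. The step from compound 2 to compound 4 is therefore expected to be smaller than the earlier one, estimated at a 3.5-fold higher number from compound 2 to compound 4 (0.55 log units; beyond the scatter). Compound 4 is expected to give about 60000 nM, plausibly between 20000 nM and 200000 nM, with a fair chance that only a limit is reported.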

Compound 4, half-maximal inhibitory concentration: > 20000 nM
Compound 4 ended at the assay's limit; the forecaster's own chance of this, stated with the estimate: 40%; the middle value is on the limit's open side.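

In this assay compound 4 gives > 20000 nM, which is a limit of the assay and not a number. The replacement of 2-oxoimidazolidin-1-yl by (ethylcarbamoyl)amino can therefore be read on this core only as a floor, an at least 1.1-fold higher number from compound 2 to compound 4 (0.07 log units; that floor lies within the scatter), so the result fits a further loss of inhibition but does not establish one, and it gives no true size for the step. Set beside the step on the other core, the result does not show whether the change carries over with the same size, only that the large step seen there has no measured counterpart here: the same change on two cores in this assay, a 1300-fold higher number (3.11 log units; beyond the scatter) from compound 3 to compound 1 and an at least 1.1-fold higher number (0.07 log units; that floor lies within the scatter) from compound 2 to compound 4; the limit leaves it open whether they differ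

The compounds shown leave open whether a methyl group or a longer chain in place of the ethyl of the (ethylcarbamoyl)amino group, or a six-membered ring in place of the five-membered ring of 2-oxoimidazolidin-1-yl, would bring the number closer to that of compound 3, at 27 nM. Going by these compounds, compound 2 and compound 3 differ in more than one place, and the part played by the core itself therefore also stays open.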